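Chain extension from compound 2 to compound 3

This account rests on a few compounds, and the source may have more. Where it says the series, first, only, none or still open, it means among the compounds named here.

Compound 1 `CCCCCCCCNc1ccn([C@H]2C[C@H](O)[C@@H](CO)O2)c(=O)n1`: 90000 nM
Compound 2 `CCCCCCCCCCNc1ccn([C@H]2C[C@H](O)[C@@H](CO)O2)c(=O)n1`: 200000 nM

In an ADME assay on A549 cells (Homo sapiens) for cytotoxicity, read by MTT assay (on this read-out higher numbers stand for lower toxicity in this test and lower numbers for higher toxicity in this test), compound 2 stands highest of the two measured compounds at 200000 nM. Compound 3 `CCCCCCCCCCCCNc1ccn([C@H]2C[C@H](O)[C@@H](CO)O2)c(=O)n1` is related to it by ethyl in place of hydrogen on a saturated chain carbon, ten or more bonds along the chain from a nitrogen on an aromatic ring. Going by the values given here, only one measured step bears on this change: ethyl in place of hydrogen, eight bonds along the chain, gave a 2.2-fold higher number from compound 1 to compound 2 (0.35 log units; beyond the scatter). That step is modest but beyond the scatter, and a single step sets no trend. A further modest rise is therefore expected, estimated as a 1.8-fold higher number from compound 2 to compound 3 (0.24 log units; within the scatter). Compound 3 is expected at 350000 nM, with an estimated range of 120000 nM to 800000 nM.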

Compound 3, half-maximal cytotoxic concentration: 100000 nM
Compound 3: the middle estimate sits 3.5-fold (0.54 log units) above what was measured; measured number outside the range, below it.
By their numbers in this assay, from the lowest: compounds 1, 3 and 2 (each within the scatter of the next, the first and the last beyond it).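

In this assay, ethyl in place of hydrogen further along the chain does not repeat the earlier step: a 2.0-fold lower number from compound 2 to compound 3 (0.30 log units; within the scatter) gives no readable change. Butyl in place of hydrogen eight bonds along the chain, with a 1.1-fold higher number from compound 1 to compound 3 (0.05 log units; within the scatter) also gives no readable change, so the one step beyond the scatter, a 2.2-fold higher number from compound 1 to compound 2 (0.35 log units; beyond the scatter) does not carry on as a trend across these three compounds. No supporting data bear on this result.

On these data alone, whether a longer chain would read beyond the scatter of these values stays open. So does the reading of an amine or a carboxylic acid on the chain.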